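Phenethyl for 4-Fluorophenyl on the Sulfur of Compound 1

A few compounds are considered here, and "the series" means these few. Any claim that something is new, unique, unknown or untested is made for them only; others in the source may bear on it.

Compound 1 `Nc1ccccc1NC(=O)/C=C/c1ccc(CSc2ccc(F)cc2)cc1`: 51.2%
Compound 2 `CC(C)(C)c1ccc(SCc2ccc(C(=O)Nc3ccccc3N)cc2)cc1`: 38.6%

Of the compounds shown here, two have so far been measured in a functional assay on A549 cells (Homo sapiens) for inhibition, read by CCK-8 assay, with a stated time of 72 h, tested at 2 uM; on this read-out higher numbers stand for more inhibition of growth at the one concentration tested and lower numbers for less inhibition of growth. Compound 1 gives 51.2%, the higher of the two numbers, and compound 2 gives 38.6%; the gap between them lies beyond the usual scatter, so compound 1 stands as the more active of the pair. Within the data shown here, no single-change step between measured compounds is available. Compound 1 and compound 2 differ in more than one place.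

Compound 3 `Nc1ccccc1NC(=O)/C=C/c1ccc(CSCCc2ccccc2)cc1` has not yet been measured. It differs from compound 1 in one place: phenethyl in place of 4-fluorophenyl on a sulfur. The sulfur keeps its other neighbour, a saturated chain carbon, and the core of compound 1 is otherwise unchanged.

Among the measured compounds shown here, with no measured step of this kind to lean on, the account can only expect a step in this assay that stays modest, most likely a small fall or none beyond the scatter. Compound 3 is therefore estimated at 45%, with a range from 25% to 65%. The expected step is a number 6.2 percentage points lower from compound 1 to compound 3 (within the scatter).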

Compound 3, percent growth inhibition at one concentration: 45.7%
Beside the measured number, compound 3's estimate is 0.7 percentage points below it; measured number inside the range.
By their numbers in this assay, from the lowest: compounds 2, 3 and 1 (each within the scatter of the next, the first and the last beyond it).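

In this assay, the exchange on the sulfur gives a number 5.5 percentage points lower from compound 1 to compound 3 (within the scatter), the first single-change step available for this part of the molecule. It shows that this position, on a sulfur whose other neighbour is a saturated chain carbon, accepts phenethyl in place of 4-fluorophenyl with no difference that can be told from the scatter, even though the fluorine is gone and the aromatic ring no longer sits directly on the sulfur. No other measurement bears on this result, so the account cannot say why the two groups read alike.

The compounds shown leave open how much wider this tolerance runs: whether benzyl, unsubstituted phenyl, a longer chain ending in phenyl, or a plain alkyl chain with no ring would read the same way, and whether an amine or a carboxylic acid at the end of such a chain would hold up as well. They also leave open whether the likeness of compound 1 and compound 3 at this single concentration would persist across a full range of concentrations.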